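Replacing the nitrophenyl amide with a pivaloyl group

This account rests on a few compounds, and the source may have more. Where it says the series, first, only, none or still open, it means among the compounds named here.

Two arylpiperazines have been measured so far. Compound 1 `COc1ccc(OC)c(N2CCN(CCCCN3C(=O)c4ccccc4C3=O)CC2)c1` carries a phthalimide on its butyl chain and in an assay on frontal cortex for binding affinity to Adrenergic receptor alpha-1 (Rattus norvegicus), read by radioligand binding (on this read-out higher numbers stand for weaker inhibition and lower numbers for stronger inhibition), compound 1 gives 15 nM. Compound 2 `COc1ccccc1N1CCN(CCCCNC(=O)c2ccc([N+](=O)[O-])cc2)CC1` instead ends in a 4-nitrobenzamide; in this assay compound 2 gives 14 nM. The two numbers lie within the scatter of each other, so neither compound can be called the tighter binder, and compound 2 simply sits alongside compound 1 at the strong end of what has been seen.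

Compound 3 `COc1ccccc1N1CCN(CCCCNC(=O)C(C)(C)C)CC1` keeps the whole of compound 2 except for one change: tert-butyl in place of 4-nitrophenyl on a carbonyl carbon. For the measured compounds named here, no measured pair shows this kind of exchange, so there is nothing in the data to set its size. The aromatic amide is removed and a small saturated branch remains, while the methoxyphenylpiperazine and the butyl linker are untouched.

For compound 3 the expected step of a 2.9-fold higher number from compound 2 to compound 3 (0.46 log units; beyond the scatter) is a modest move toward weaker inhibition, and its value in this assay is estimated at 40 nM, with a likely range from 12 nM to 150 nM.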

Compound 3, inhibition constant: 74 nM
Compound 3: the middle estimate sits 1.9-fold (0.27 log units) below what was measured, and the stated range covers the measured number.
By their numbers in this assay, from the lowest: compounds 2 and 1 (each within the scatter of the next); then compound 3.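

For the compounds shown here, until this pair, no two compounds differing in one place had been available, so the data could not say whether the group on this carbonyl carbon affects the number at all. In this assay, tert-butyl in place of 4-nitrophenyl gives a 5.3-fold higher number from compound 2 to compound 3 (0.72 log units; beyond the scatter), a modest step but one beyond the scatter, so with the rest of the molecule unchanged this position is shown to bear on the read-out, and a saturated branch with no ring is tolerated only at some cost. Nothing on hand offers a measured reason for the size of this step.

The exchange removes the aromatic ring and the nitro group together, so the pair cannot show how much of the step belongs to each of them; a plain phenyl on the same carbonyl carbon would separate the two. Going by these compounds, a cyclohexyl group there would likewise test whether a ring without aromatic character behaves more like 4-nitrophenyl or more like tert-butyl, and that also remains open.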